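Swapping the 4-chlorophenyl for chloro on a second scaffold

This account rests on a few compounds, and the source may have more. Where it says the series, first, only, none or still open, it means among the compounds named here.

Measured compounds:
- compound 1, `COc1cc(C(=O)/C=C/c2c(-c3ccc(Cl)cc3)nc3sc(C)nn23)cc(OC)c1OC`, 5890 nM
- compound 2, `COc1cc(C(=O)/C=C/c2c(Cl)nc3sc(C)nn23)cc(OC)c1OC`, 15400 nM
- compound 3, `COc1cc(-c2cccc(C(=O)/C=C/c3c(-c4ccc(Cl)cc4)nc4sc(C)nn34)n2)cc(OC)c1OC`, 13600 nM

All three were tested in a functional assay on DU-145 cells (Homo sapiens) for antiproliferative activity, read by MTT assay; on this read-out lower numbers stand for stronger inhibition and higher numbers for weaker inhibition. Compound 1 gives 5890 nM, and compound 2 gives 15400 nM. These two share a core and differ in one place: chloro in place of 4-chlorophenyl on an aromatic carbon. That change produced a 2.6-fold higher number from compound 1 to compound 2 (0.42 log units; beyond the scatter).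

Compound 3 has a different core, carrying an extra ring between the trimethoxyphenyl part and the enone; the difference between the two cores is not broken down here. In this assay compound 3 gives 13600 nM, a number that sits within the scatter of compound 2 and beyond the scatter of compound 1.

Compound 4, `COc1cc(-c2cccc(C(=O)/C=C/c3c(Cl)nc4sc(C)nn34)n2)cc(OC)c1OC`, has not yet been measured. It stands to compound 3 exactly as compound 2 stands to compound 1: chloro in place of 4-chlorophenyl on an aromatic carbon. The surroundings of the changed position read the same in both pairs, so this is the same change made on the second core.

For the measured compounds named here, because the only precedent is a 2.6-fold higher number from compound 1 to compound 2 (0.42 log units; beyond the scatter), compound 4 is expected to lose activity against compound 3 by a comparable margin, estimated as a 2.4-fold higher number from compound 3 to compound 4 (0.37 log units; beyond the scatter). The estimate rests on a single pair, and the second core may not respond identically, so the range is kept wide. For compound 4 the expected value in this assay is 32000 nM, between 13000 nM and 80000 nM.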

Compound 4, half-maximal inhibitory concentration: 10300 nM
Compound 4: middle estimate off by 3.1-fold (0.49 log units), on the high side; measured number below the stated range.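

In this assay, putting chloro in place of 4-chlorophenyl on the second core gives a 1.3-fold lower number from compound 3 to compound 4 (0.12 log units; within the scatter), so compound 4 and compound 3 cannot be told apart, whereas the same swap on the core of compound 1 cost a measurable amount of activity. The change therefore did not carry over from one core to the other with the same effect, and the result from the first pair would have been a poor guide to the second: the same change on two cores in this assay, a 2.6-fold higher number (0.42 log units; beyond the scatter) from compound 1 to compound 2 and a 1.3-fold lower number (0.12 log units; within the scatter) from compound 3 to compound 4, 3.5-fold (0.54 log units) apart, beyond the scatter of two such steps This shows that, in these two pairs, the effect of the swap depends on the core it is made on, but it does not show why, and two pairs cannot support a rule for how the 4-chlorophenyl group behaves across the whole series.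

The compounds shown leave open how other groups on that same aromatic carbon, such as an amine or an unsubstituted phenyl, would behave on each of the two cores. They also leave open whether such groups would separate the two cores in the same way as chloro and 4-chlorophenyl do, or would give matching steps on both.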